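This account rests on a few compounds, and the source may have more. Where it says the series, first, only, none or still open, it means among the compounds named here.

Among the measured compounds shown here, in a functional assay on HepG2 cells (Homo sapiens) for inhibition, read by MTT assay, with a stated time of 24 h (a higher number here means a weaker inhibitor of growth, a lower number a stronger inhibitor of growth), compound 1 `COc1ccc(C(=O)n2c(-c3cn(C)c4ccc(OC)cc34)nc3ccccc32)cc1` gives 12800 nM and compound 2 `COc1ccc2c(c1)c(-c1nc3ccccc3n1C(=O)c1ccc(OC)c(OC)c1)cn2C` gives 5100 nM, the lower of the two numbers so far. For the measured compounds named here, the one measured step shows a 2.5-fold lower number from compound 1 to compound 2 (0.40 log units; beyond the scatter), with methoxy in place of hydrogen on an aromatic carbon. Compound 3 `COc1ccc(C(=O)n2c(-c3cn(C)c4ccc(Br)cc34)nc3ccccc32)cc1OC` differs from compound 2 at another place: it has bromo in place of methoxy on an aromatic carbon of a six-membered aromatic ring of carbon only, part of a fused or bridged system of two rings (bromo in place of methoxy on an aromatic carbon). Going by the values given here, the modest measured step therefore does not test this change, and no measured compound carries bromo. The expectation stays close to compound 2 at 5100 nM, with no favoured direction and no step beyond the scatter in this assay. The estimated change is a 1.0-fold lower number from compound 2 to compound 3 (0.01 log units; within the scatter). Compound 3 is expected at about 5000 nM, with an estimated range of 1800 nM to 14000 nM.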

Compound 3, concentration for 50% growth inhibition: 9700 nM
For compound 3 the middle estimate is 1.9-fold (0.29 log units) below the measured one; measured number inside the range.
By their numbers in this assay, from the lowest: compounds 2, 3 and 1 (each within the scatter of the next, the first and the last beyond it).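

In this assay, putting bromo in place of methoxy on this aromatic carbon of the fused two-ring system gives a 1.9-fold higher number from compound 2 to compound 3 (0.28 log units; within the scatter), so the two compounds cannot be told apart. At this place, then, the methoxy group, with its hydrogen-bond acceptor, can be exchanged for bromo, which has none, without a difference that rises above the ordinary variation between repeated measurements. No independent measurement is available to explain this result.

The compounds shown carry only methoxy or bromo at this place, so it remains open whether an amine or a carboxylic acid here would give a clearly different number. As far as these compounds go, it also remains open whether bromo would give a similar result on the core of compound 1.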